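The source may hold more compounds than are shown below. What is called first, only, known or untested is meant among the compounds shown, and "the series" means these compounds.

Working notes on the series in an ADME assay on L1210/0 cells (Mus musculus) for cytotoxicity, with a stated time of 48 h; on this read-out lower numbers stand for stronger inhibition and higher numbers for weaker inhibition:

- compound 1 `Nc1ncnc2c1ncn2C[C@@H]1C[C@H](O)c2ccccc21`: > 200000 nM (a limit)
- compound 2 `Cc1ccc(S(=O)(=O)/C=C/[C@H]2O[C@@H](n3cnc4c(N)ncnc43)[C@@H](O)[C@H]2O)cc1`: 54000 nM
- compound 3 `C[C@@]1(CO)O[C@H](c2cc(F)c(N)cc2F)C[C@@H]1O`: > 200000 nM (a limit)

Only compound 2 gives a number in this assay. The other two values stand at the limit of > 200000 nM in this assay, at which 2 of the 3 values shown sit.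

Compound 3 gives > 200000 nM, which is a limit and not a number. The next compound to be read is compound 4 `C[C@@]1(CO)O[C@H](c2ccc(N)cc2F)C[C@@H]1O`. It differs from compound 3 in one place: hydrogen in place of fluoro on an aromatic carbon. In words, hydrogen takes the place of fluoro on an aromatic carbon, ortho to an amino group and para to a fluoro group.

Among the compounds with values here, no measured pair differs in a single place, so this expectation rests on compound 3 alone. The expected change in this assay is a number no higher from compound 3 to compound 4 (the limit leaves the size open), with no shift beyond the scatter expected in either direction. A report of a limit again is the likely outcome. For compound 4 the estimated value is 200000 nM. The expected range for compound 4 runs from 90000 nM to 400000 nM.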

Compound 4, half-maximal inhibitory concentration: > 200000 nM
Compound 4: a limit, no number; the forecaster's own chance of this, stated with the estimate: 70%; the middle value lies on the limit itself.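

Compound 3 and compound 4 both give only a limit in this assay, so no new step can be read between them: the limit of > 200000 nM in this assay, at which 3 of the 4 values shown sit.

The compounds shown leave open whether hydrogen in place of fluoro on an aromatic carbon shifts this read-out at all.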